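From Secondary Amide to Difluoromethyl Piperidine Amide

This account rests on a few compounds, and the source may have more. Where it says the series, first, only, none or still open, it means among the compounds named here.

Of the compounds shown here, two have been measured in a functional assay on MIA PaCa-2 cells (Homo sapiens) for inhibition, read by MTT assay, with a stated time of 7 days; on this read-out lower numbers stand for stronger inhibition and higher numbers for weaker inhibition. Compound 1 `O=C([C@@H]1CCCN(S(=O)(=O)c2ccc(S(=O)(=O)N3CC[C@@H](O)C3)cc2)C1)N1CCC(F)(F)CC1` gives 210 nM in this assay, while compound 2 `CCN(CC)S(=O)(=O)c1ccc(S(=O)(=O)N2CCC[C@@H](C(=O)N[C@H]3CCOC3)C2)cc1` gives 1670 nM, the higher of the two numbers, with compound 1 sitting at a lower number by a margin that lies beyond the usual scatter. For the measured compounds named here, the two compounds differ in more than one place, so no single step between them can be read.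

Compound 3 `CCN(CC)S(=O)(=O)c1ccc(S(=O)(=O)N2CCC[C@@H](C(=O)N3CCC(C(F)F)CC3)C2)cc1` keeps the core of compound 2 and alters the amide: 4-(difluoromethyl)piperidin-1-yl in place of (oxolan-3-yl)amino on a carbonyl carbon. The step from compound 2 to compound 3 is therefore uncharted by any measured pair. Going by the values given here, on this read-out compound 3 is expected to reach a lower number than compound 2, a moderate step of a 2.8-fold lower number from compound 2 to compound 3 (0.44 log units; beyond the scatter), though with wide uncertainty since only two values exist. Compound 3 is estimated at 600 nM, within a range of 200 nM to 2000 nM.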

Compound 3, half-maximal inhibitory concentration: 420 nM
The estimate for compound 3 lay 1.4-fold (0.15 log units) above the measured number, and the stated range covers the measured number.
By their numbers in this assay, from the lowest: compounds 1 and 3 (each within the scatter of the next); then compound 2.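

In this assay, for the compounds shown here, the change on the carbonyl carbon from (oxolan-3-yl)amino to 4-(difluoromethyl)piperidin-1-yl gives a 4.0-fold lower number from compound 2 to compound 3 (0.60 log units; beyond the scatter) and is the only step in this set that can be read. It shows that, with the rest of compound 2 unchanged, the number responds to the group at this position, and that it falls beyond the scatter even though the entering group has no hydrogen-bond donor or acceptor and the leaving group had one of each. Nothing available explains this step.

Because the change replaces the ring, the amide hydrogen and the fluorine atoms together, the step does not separate their contributions, and a plain piperidin-1-yl or a morpholin-4-yl at this position would bear on that question. Steps involving compound 1 cannot be read, since it differs from the other compounds in more than one place.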